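From Sulfamoyl to Methylsulfonyl on the Chain

A few compounds are considered here, and "the series" means these few. Any claim that something is new, unique, unknown or untested is made for them only; others in the source may bear on it.

Within the data shown here, in a functional assay on the whole organism with Rattus norvegicus as the target (on this read-out higher numbers stand for an effect only at larger amounts of compound and lower numbers for an effect already at smaller amounts), compound 2 `N=c1sc2cc(OC(F)(F)F)ccc2n1CCS(N)(=O)=O` gives 6 mg/kg and stands as the only true number among the values shown. Compound 1 `Nc1nc2ccc(I)cc2s1` gives only > 10 mg/kg in this assay, which is a limit and not a number. Compound 3 `CS(=O)(=O)CCCn1c(=N)sc2cc(OC(F)(F)F)ccc21` has not yet been measured and differs from compound 2 by (methylsulfonyl)methyl in place of sulfamoyl on a saturated chain carbon, two bonds along the chain from an aromatic nitrogen in this single place. Among the measured compounds shown here, no measured pair shows a change of this kind, so the step of no change at the digits printed from compound 2 to compound 3 (within the scatter) is expected to stay within the usual scatter with no clear direction. Compound 3 is therefore estimated at 6 mg/kg with a range from 3 mg/kg to 12 mg/kg in this assay.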

Compound 3, dose for half-maximal effect: 5 mg/kg
For compound 3 the middle estimate is 1.2-fold (0.08 log units) above the measured one, and the stated range covers the measured number.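

In this assay, among these compounds, a 1.2-fold lower number from compound 2 to compound 3 (0.08 log units; within the scatter), the first reading of any change at this place on the chain. Sulfamoyl has a hydrogen-bond donor and (methylsulfonyl)methyl has none, yet the two compounds read alike, so in this pair the donor is not required for an effect at this dose level. Nothing shown here explains why the two groups read alike.

From the compounds shown here alone, whether an amine or a carboxylic acid at this place would read the same stays open. A single pair also cannot show how a longer chain would read.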